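Acrylamide quinazoline series: fluorine replaces methyl on the aniline

A few compounds are considered here, and "the series" means these few. Any claim that something is new, unique, unknown or untested is made for them only; others in the source may bear on it.

Measured compounds:
compound 1, `C=CC(=O)Nc1cccc(NC(=O)CSc2nc(Nc3ccccc3)c3ccccc3n2)c1`, 10200 nM
compound 2, `C=CC(=O)Nc1cccc(NC(=O)CSc2nc(Nc3ccccc3Cl)c3ccccc3n2)c1`, 12700 nM
compound 3, `C=CC(=O)Nc1cccc(NC(=O)CSc2nc(Nc3ccccc3C)c3ccccc3n2)c1`, 20400 nM

Three compounds sharing one core were tested in a functional assay on MDA-MB-231 cells (Homo sapiens) for inhibition, read by MTT assay, with a stated time of 72 h; a lower number here means a stronger inhibitor, a higher number a weaker inhibitor. Compound 1 carries an unsubstituted phenyl on the ring nitrogen and gives 10200 nM. Compound 2 carries a chlorine on that phenyl and gives 12700 nM. Compound 3 carries a methyl there and gives 20400 nM. Every step among them is small: a 1.2-fold higher number from compound 1 to compound 2 (0.10 log units; within the scatter), a 2.0-fold higher number from compound 1 to compound 3 (0.30 log units; within the scatter) and a 1.6-fold higher number from compound 2 to compound 3 (0.21 log units; within the scatter). Compound 3 is therefore not separated from the other two by anything beyond the scatter.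

Compound 4, `C=CC(=O)Nc1cccc(NC(=O)CSc2nc(Nc3cccc(F)c3)c3ccccc3n2)c1`, differs from compound 3 by 3-fluorophenyl in place of 2-methylphenyl on a nitrogen on an aromatic ring. Within the data shown here, no measured pair introduces a fluorine, so the bearing steps are indirect: the methyl that enters in a 2.0-fold higher number from compound 1 to compound 3 (0.30 log units; within the scatter) and the exchange in a 1.6-fold higher number from compound 2 to compound 3 (0.21 log units; within the scatter) both stayed within the scatter. Since changes on this phenyl have not moved the number beyond the scatter in any measured step, a similar outcome is expected in this assay.

For compound 4 a step of a 1.6-fold lower number from compound 3 to compound 4 (0.20 log units; within the scatter) is expected. The estimated value for compound 4 is 13000 nM, expected to fall between 6000 nM and 28000 nM.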

Compound 4, half-maximal inhibitory concentration: 8160 nM
The estimate for compound 4 lay 1.6-fold (0.20 log units) above the measured number, and the stated range covers the measured number.
By their numbers in this assay, from the lowest: compounds 4, 1, 2 and 3 (each within the scatter of the next, the first and the last beyond it).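

In this assay the step from 2-methylphenyl to 3-fluorophenyl on the nitrogen gives a 2.5-fold lower number from compound 3 to compound 4 (0.40 log units; beyond the scatter), the only step among these compounds that passes beyond the scatter, so a change on this phenyl can separate two compounds, though only modestly. That separation is confined to this one pair: the other two steps, a 1.6-fold lower number from compound 2 to compound 4 (0.19 log units; within the scatter) and a 1.3-fold lower number from compound 1 to compound 4 (0.10 log units; within the scatter), stay within the scatter, so 3-fluorophenyl is not set apart from 2-chlorophenyl or from the unsubstituted phenyl, and adding a fluorine to the unsubstituted phenyl shows no clear effect. The data shown offer no explanation for the one step that passes the scatter.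

From the compounds shown here alone, since this step alters both the group and its place on the phenyl, it remains open which of the two matters, a question that a pair such as 2-fluorophenyl and 3-methylphenyl would address. Also open, going by these compounds, is whether a different kind of group on this phenyl, such as a methoxy, an amine or a carboxylic acid, would move the number further than the halogens and the methyl do.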